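Shortening the Octyl Chain and Cytotoxicity in HeLa Cells

The source may report more compounds than this note shows. Statements on the series, on what has been measured and on what is new or still open speak of the compounds shown alone.

Compound 3 `CCCCCCCCc1ccc(-c2cc3cn([C@H]4C[C@H](O)[C@@H](CO)O4)c(=O)nc3s2)cc1` is the octyl member of three analogues that share one core. In a functional assay on HeLa cells (Homo sapiens) for cytotoxicity (on this read-out higher numbers stand for lower toxicity in this test and lower numbers for higher toxicity in this test), compound 3 gives only the limit > 200000 nM and no number. Compound 1 `CCCc1ccc(-c2cc3cn([C@H]4C[C@H](O)[C@@H](CO)O4)c(=O)nc3s2)cc1`, the propyl analogue, likewise reaches only the limit > 200000 nM. Compound 2 `CCCCc1ccc(-c2cc3cn([C@H]4C[C@H](O)[C@@H](CO)O4)c(=O)nc3s2)cc1`, the butyl analogue, also sits at the limit > 200000 nM. The steps a step that the two limits leave unreadable from compound 1 to compound 2, a step that the two limits leave unreadable from compound 1 to compound 3 and a step that the two limits leave unreadable from compound 2 to compound 3 therefore cannot be read, because of the limit of > 200000 nM in this assay, at which 3 of the 3 values shown sit. Compound 4 `CCCCCCc1ccc(-c2cc3cn([C@H]4C[C@H](O)[C@@H](CO)O4)c(=O)nc3s2)cc1` differs from compound 3 by hydrogen in place of ethyl on a saturated chain carbon, six bonds along the chain from an aromatic carbon. All three measured steps change only the chain length and none leaves the limit, so no readable change is expected for the step that the limit leaves unreadable from compound 3 to compound 4. Compound 4 is therefore expected to give about 300000 nM, within 150000 nM to 1000000 nM, most likely again only as a limit.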

Compound 4, half-maximal cytotoxic concentration: > 200000 nM
Compound 4 was reported as a limit; the forecaster's own chance of this, stated with the estimate: 85%; the middle value lies beyond the limit too.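

No step among compound 1, compound 2, compound 3 and compound 4 can be read, because each gives only a limit and no number: the limit of > 200000 nM in this assay, at which 4 of the 4 values shown sit.

On these data alone, whether chain length changes toxicity in these cells at all remains open.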